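Cyclopropyl in Place of Pyridin-4-yl in Compound 4

The source may report more compounds than this note shows. Statements on the series, on what has been measured and on what is new or still open speak of the compounds shown alone.

Compound 1 `CN(C)Cc1nccn1-c1ccc(Cl)cc1C(=O)c1ccccc1Cl` gives 11 mg/kg in a functional assay on the whole organism (strain CF-1) with Mus musculus as the target (on this read-out lower numbers stand for an effect already at smaller amounts and higher numbers for an effect only at larger amounts of compound), and compound 2 `Cc1nnc(CN)n1-c1ccc(Cl)cc1C(O)c1ccccc1` gives 9 mg/kg. Compound 3 `CN(C)Cc1nnc(-c2ccncc2)n1-c1ccc(Cl)cc1C(=O)c1ccccc1Cl` reaches in this assay only a limit of the assay, > 100 mg/kg, and not a number; that is the limit of > 100 mg/kg in this assay, at which 1 of the 3 values shown sits. Compound 4 `CN(C)Cc1nnc(C2CC2)n1-c1ccc(Cl)cc1C(=O)c1ccccc1Cl` differs from compound 3 by a single change, (cyclopropyl in place of pyridin-4-yl on an aromatic carbon). No measured step connects these compounds, but compounds 1 and 2, which lack the pyridin-4-yl, sit at the numbers shown rather than at the limit, so a move toward smaller doses in this assay is expected, the step of an at least 3.3-fold lower number from compound 3 to compound 4 (0.52 log units; beyond the scatter) being estimated as larger than the usual scatter. Compound 4 is therefore expected to give 30 mg/kg in this assay, within a range from 10 mg/kg to 100 mg/kg.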

Compound 4, dose for half-maximal effect: 7.1 mg/kg
Compound 4: middle estimate off by 4.2-fold (0.63 log units), on the high side; measured number outside the range, below it.
By their numbers in this assay, from the lowest: compounds 4, 2 and 1 (each within the scatter of the next). At a limit, above all of these: compound 3.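

In this assay, for the compounds shown here, cyclopropyl in place of pyridin-4-yl gives an at least 14-fold lower number from compound 3 to compound 4 (1.14 log units; beyond the scatter), the first step here that isolates a single change at this carbon of the five-membered ring. With the (dimethylamino)methyl group kept, the choice of group at this one place separates a number from no measurable effect. Compound 3 stands at a limit of the assay, so the step has a bound but no exact size: the limit of > 100 mg/kg in this assay, at which 1 of the 4 values shown sits.

The compounds shown leave open whether phenyl would behave like pyridin-4-yl or like cyclopropyl. As far as these compounds go, whether methyl or a longer chain would serve here also remains open.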